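The compounds below may be only part of what the source reports. "The series", "measured", "known", "first", "only" and "open" are said of these compounds alone.

Working notes on the series. The shared core of compound 3 `CCCC[C@]1(CC)CS(=O)(=O)c2ccc(N)cc2[C@@H](c2ccccc2)[C@H]1O` carries an amino group on the aromatic ring fused to the sulfone. In an assay on cells for inhibition of ileal sodium/bile acid cotransporter (Homo sapiens) (a lower number here means a stronger inhibitor, a higher number a weaker inhibitor), compound 3 gives 68 nM, the lowest of the three numbers to hand. Its nearest neighbour on the numbers is compound 1 `CCCC[C@]1(CC)CS(=O)(=O)c2ccc(-c3ccccc3)cc2[C@@H](c2cccc(OC)c2)[C@H]1O`, which in this assay gives 180 nM, a gap beyond the scatter. Compound 2 `C=CCCCCCCCCOc1ccc2c(c1)S(=O)(=O)C[C@@](CC)(CCCC)[C@H](O)[C@@H]2c1ccccc1` differs from compound 3 in several places. In this assay compound 2 gives 16000 nM and stands far above both.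

Compound 4 `CCCC[C@]1(CC)CS(=O)(=O)c2ccc(NC(=O)OCc3ccccc3)cc2[C@@H](c2ccccc2)[C@H]1O` is not yet measured. It differs from compound 3 in one place: benzyloxycarbonyl in place of hydrogen on a nitrogen on an aromatic ring. For the measured compounds named here, no measured pair in this set isolates that change, so the direction of the step rests on the tolerance the core shows for a phenyl substituent in compound 1 alone. A modest loss is expected, a 2.2-fold higher number from compound 3 to compound 4 (0.34 log units; beyond the scatter), of a size near the edge of the scatter. Compound 4 is therefore estimated at 150 nM in this assay, with a range from 40 nM to 600 nM.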

Compound 4, half-maximal inhibitory concentration: 400 nM
Estimate against measurement, compound 4: 2.7-fold (0.43 log units) below, and the stated range covers the measured number.
By their numbers in this assay, from the lowest: compound 3; then compound 1; then compound 4; then compound 2.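

Benzyloxycarbonyl in place of hydrogen on a nitrogen on an aromatic ring gives, in this assay, a 5.9-fold higher number from compound 3 to compound 4 (0.77 log units; beyond the scatter), the first reading of a single change at this position. The step is a real but modest loss, so the shared core keeps its inhibition when this nitrogen carries a group of 10 heavy atoms with a six-membered aromatic ring. Nothing to hand gives a cause for this step.

The compounds shown leave open how an acetyl group or a single methyl on this nitrogen would read, and so whether the loss goes with the carbonyl or with the benzyl part. Also open, on these data alone, is how a carboxylic acid or an amine on the benzyl ring would shift the number.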